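Chloro to fluoro exchange on the urea aryl ring

A few compounds are considered here, and "the series" means these few. Any claim that something is new, unique, unknown or untested is made for them only; others in the source may bear on it.

Measured compounds:
compound 1 `CC(C)N(CCN(C(=O)Nc1cccc(F)c1)C1CC[C@]2(c3cccc(C#N)c3)CC2C1)C(C)C`: 2.1 nM
compound 2 `CC(C)N(CCN(C(=O)Nc1cccc(Cl)c1)C1CC[C@]2(c3cccc(C#N)c3)CC2C1)C(C)C`: 6 nM
compound 3 `CS(=O)(=O)N1CCC(CN(C(=O)Nc2ccc(F)c(Cl)c2)C2CC[C@]3(c4cccc(C#N)c4)CC3C2)CC1`: 7.19 nM

All three share the same bicyclic core bearing the nitrile-substituted phenyl group and a urea linked to a halogenated aryl ring; they differ in the amine side chain and in the aryl halogen pattern. In a functional assay for antagonist activity at melanin-concentrating hormone receptor 1 (Homo sapiens) (on this read-out lower numbers stand for stronger inhibition and higher numbers for weaker inhibition), compound 1 gives 2.1 nM and compound 2 gives 6 nM. The only counted difference between these two is fluoro in place of chloro on an aromatic carbon, and it produced a 2.9-fold lower number from compound 2 to compound 1 (0.46 log units; beyond the scatter). Compound 3 gives 7.19 nM in this assay; its values lies close to that of compound 2, and its difference from compound 2 is not broken down here, since the two differ in more than one place.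

Compound 4 `CS(=O)(=O)N1CCC(CN(C(=O)Nc2ccc(F)c(F)c2)C2CC[C@]3(c4cccc(C#N)c4)CC3C2)CC1` has not yet been measured. It stands to compound 3 as compound 1 stands to compound 2: fluoro in place of chloro on an aromatic carbon. The surroundings are not identical, however; in compound 3 the exchanged carbon is also ortho to a fluoro group, whereas in compound 2 it is not, so this is the same kind of change rather than the same change. Resting on the single precedent given by compound 2 to compound 1, a 2.9-fold lower number from compound 2 to compound 1 (0.46 log units; beyond the scatter), a step of comparable direction and somewhat smaller size is expected, a 2.1-fold lower number from compound 3 to compound 4 (0.31 log units; beyond the scatter). Within the data shown here, compound 4 is therefore estimated at 3.5 nM in this assay, with a range from 1.5 nM to 8 nM, the width reflecting that only one example of this change is available and that its surroundings differ.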

Compound 4, inhibition constant: 5.4 nM
Compound 4: middle estimate off by 1.5-fold (0.19 log units), on the low side, and the stated range covers the measured number.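

In this assay, among these compounds, replacing 3-chloro-4-fluorophenyl with 3,4-difluorophenyl gives a 1.3-fold lower number from compound 3 to compound 4 (0.12 log units; within the scatter), so on this core the exchange cannot be told apart from no step at all. Set beside the earlier pair, the two results do not separate from each other: the same change on two cores in this assay, a 2.9-fold lower number (0.46 log units; beyond the scatter) from compound 2 to compound 1 and a 1.3-fold lower number (0.12 log units; within the scatter) from compound 3 to compound 4, 2.1-fold (0.33 log units) apart, within the scatter of two such steps. The exchange therefore has no result on either core that contradicts the other, but this does not show that its size carries over, since one step lies beyond the scatter and the other within it, and two pairs are too few to establish either transfer or dependence on the core.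

The two pairs differ both in the amine side chain and in whether the exchanged carbon is ortho to a fluoro group, so the side chain of compound 3 paired with the aryl rings of compound 1 and compound 2 would be needed to tell these two differences apart. Also open, going by these compounds, is how a methyl, methoxy or trifluoromethyl group at the same aromatic carbon would compare with chloro and fluoro on either core.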